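A few compounds are considered here, and "the series" means these few. Any claim that something is new, unique, unknown or untested is made for them only; others in the source may bear on it.

Working notes on the series. Compound 1 `CNCc1cn(S(=O)(=O)c2cccs2)c(-c2cccnc2F)c1F` and compound 2 `CNCc1cn(S(=O)(=O)c2ccoc2)c(-c2cccnc2F)c1F` share the core and differ only on the sulfonyl sulfur. In a functional assay on the whole organism (strain Jcl:Sprague-Dawley) for inhibition, with Rattus norvegicus as the target, with stated times of 3 min and 3 h, at a dose of 1 mg/kg by the intravenous route (on this read-out higher numbers stand for more inhibition at the one dose given (going by the name of the read-out) and lower numbers for less inhibition), compound 1 gives 98%, and compound 2 gives 95%; the step of a number 3 percentage points lower from compound 1 to compound 2 (within the scatter) shows that the change on the sulfonyl sulfur leaves the read-out unchanged within the scatter. Compound 3 `CNCc1cn(S(=O)(=O)c2cncc(Cl)c2)c(-c2cccnc2F)c1F` carries a 5-chloropyridin-3-yl on the sulfonyl sulfur; in this assay compound 3 is reported as "not determined" (no result reported), so compound 3 cannot be placed against compound 1 or compound 2 on the measurements.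

Compound 4 `CNCc1cn(S(=O)(=O)c2cncc(F)c2)c(-c2cccnc2F)c1F` differs from compound 3 by fluoro in place of chloro on an aromatic carbon. Going by the values given here, no measured step in this set exchanges chloro for fluoro, and the only measured step, from compound 1 to compound 2, concerns a different part of the molecule, so no size or direction can be read off for the step to compound 4 in this assay; all that the data offer is that the numbers of compound 1 and compound 2 in this assay are level with each other within the scatter. On that basis compound 4 is expected to give about 90% in this assay, with a plausible range from 65% to 99%.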

Compound 4, a percentage reported as inhibition, in the whole organism at one dose (the size of the read-out at that dose, not a potency) in the Rattus norvegicus assay: 99%
For compound 4 the middle estimate is 9 percentage points below the measured one, within the range that was stated.
By their numbers in the Rattus norvegicus assay, from the lowest: compounds 2, 1 and 4 (each within the scatter of the next).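

With 5-fluoropyridin-3-yl on the sulfonyl sulfur, the read-out in the Rattus norvegicus assay stays level with the thiophen-2-yl and furan-3-yl compounds: a number 4 percentage points higher from compound 2 to compound 4 (within the scatter), and a number 1 percentage points higher from compound 1 to compound 4 (within the scatter). The sulfonyl sulfur thus carries a six-membered aromatic ring with 1 nitrogen with no difference beyond the scatter at this one dose, which compound 1 and compound 2 alone could not show. In a physicochemical assay for lipophilicity, read by HPLC, at pH 7.4 (on this read-out higher numbers stand for higher lipophilicity and lower numbers for lower lipophilicity), compound 3 gives 1.44 and compound 4 gives 0.83, that is a number 0.61 log units lower from compound 3 to compound 4 (beyond the scatter), so fluoro in place of chloro on this ring moves this read-out.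

The same exchange cannot be read in the Rattus norvegicus assay, as compound 3 has no number there. Open too, as far as these compounds go, is how an amine or a carboxylic acid in place of fluoro on this ring would read in either assay.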